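A few compounds are considered here, and "the series" means these few. Any claim that something is new, unique, unknown or untested is made for them only; others in the source may bear on it.

Compound 2 `O=C(CCN1CCN(c2ccnc3cc(Cl)ccc23)CC1)N/N=C/c1ccc(Cl)cc1` gives the lower of the two numbers in an ADME assay on cells (Splenocyte, Mus musculus, strain BALB/c) for cytotoxicity, read by thymidine incorporation, with a stated time of 24 h (a lower number here means a stronger inhibitor, a higher number a weaker inhibitor), at 200 nM; compound 1 `O=C(CCN1CCN(c2ccnc3cc(Cl)ccc23)CC1)N/N=C/c1c[nH]c2ccccc12` gives 5700 nM, and the change recorded from compound 1 to compound 2 was a 29-fold lower number from compound 1 to compound 2 (1.45 log units; beyond the scatter). Compound 3 `CC(C)c1ccc(/C=N/NC(=O)CCN2CCN(c3ccnc4cc(Cl)ccc34)CC2)cc1` carries isopropyl in place of chloro on an aromatic carbon. Within the data shown here, no measured step swaps one group for another on this ring, so the single known step does not speak to this change directly. A step within the usual scatter is therefore expected, a 1.5-fold higher number from compound 2 to compound 3 (0.18 log units; within the scatter), and compound 3 is estimated at 300 nM, between 80 nM and 1200 nM.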

Compound 3, half-maximal inhibitory concentration: 7900 nM
Compound 3: middle estimate off by 26-fold (1.42 log units), on the low side; the whole stated range lies below it.
By their numbers in this assay, from the lowest: compound 2; then compounds 1 and 3 (each within the scatter of the next).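

In this assay, the group on this ring is far from a neutral choice: isopropyl in place of chloro gives a 40-fold higher number from compound 2 to compound 3 (1.60 log units; beyond the scatter) and removes the whole advantage of the 4-chlorophenyl compound. Putting 4-isopropylphenyl in place of 1H-indol-3-yl gives a 1.4-fold higher number from compound 1 to compound 3 (0.14 log units; within the scatter) and so no real change, which shows that a phenyl ring alone does not bring the low number. Nothing available explains this large step. Still open, on these data alone, is how fluoro, methyl or dimethylamino would behave at this place on the ring.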